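This account rests on a few compounds, and the source may have more. Where it says the series, first, only, none or still open, it means among the compounds named here.

Compound 1 `COc1ccc(C2CC(c3ccccc3)=NN2c2nc(-c3ccccc3)c(C#N)c(=O)n2C)cc1` was tested in a functional assay on MDA-MB-231 cells (Homo sapiens) for antiproliferative activity, with a stated time of 72 h (on this read-out higher numbers stand for weaker inhibition and lower numbers for stronger inhibition), where compound 1 gives 12800 nM. Going by the values given here, of the two numbers measured, compound 1 has the highest, but its only neighbour sits very close: compound 2 `Cn1c(N2N=C(c3ccccc3)CC2c2ccc(F)cc2)nc(-c2ccccc2)c(C#N)c1=O`, which gives 11800 nM in this assay, and the change a 1.1-fold lower number from compound 1 to compound 2 (0.04 log units; within the scatter) is too small to tell the two apart.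

Compound 3 `COc1ccc(C2=NN(c3nc(-c4ccccc4)c(C#N)c(=O)n3C)C(c3ccc(OC)cc3)C2)cc1` has not yet been measured. It differs from compound 1 by methoxy in place of hydrogen on an aromatic carbon, on an aromatic carbon of a six-membered aromatic ring of carbon only. Among the compounds with values here, no measured step adds a methoxy group to a ring that carries none; the single step available, from compound 1 to compound 2, exchanges one group for another and stayed within the scatter. With nothing pointing either way, no movement beyond the scatter is expected in this assay. Compound 3 is therefore estimated at 12000 nM, within a range of 5000 nM to 30000 nM, a step of a 1.1-fold lower number from compound 1 to compound 3 (0.03 log units; within the scatter) that is expected to stay within the scatter.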

Compound 3, half-maximal inhibitory concentration: 16200 nM
Compound 3: middle estimate off by 1.4-fold (0.13 log units), on the low side; the range from low to high includes it.
By their numbers in this assay, from the lowest: compounds 2, 1 and 3 (each within the scatter of the next).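

In this assay turning phenyl into 4-methoxyphenyl gives a 1.3-fold higher number from compound 1 to compound 3 (0.10 log units; within the scatter) and so leaves the read-out indistinguishable from the starting compound. Going by these compounds alone, this is the first view of a group added where only a hydrogen stood, since the earlier step exchanged one group for another on a different aromatic ring. Here too, a methoxy group para to a large group produces no change that can be separated from the ordinary spread of repeated measurements, and no supporting data are available to explain this result.

Going by these compounds, whether this position responds to a group of a different kind remains open, such as an amine, a carboxylic acid or a longer chain. It is also unclear whether any change at this position can move the value beyond the scatter.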